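The source may hold more compounds than are shown below. What is called first, only, known or untested is meant among the compounds shown, and "the series" means these compounds.

Working notes on the series.

Compound 2 `COC(=O)[C@@]1(C)CC[C@@H]2C3=C1CC[C@@H](C)[C@]3(C)Cc1c2[nH]c2ccc(C)cc12` holds the shared core with a methyl on an aromatic carbon. In a functional assay on SW1573 cells (Homo sapiens) for inhibition, read by sulforhodamine B assay, with a stated time of 48 h (a higher number here means a weaker inhibitor of growth, a lower number a stronger inhibitor of growth), compound 2 gives 15000 nM. Among the two numbers so far this is the higher one, with compound 1 `COC(=O)[C@@]1(C)CC[C@@H]2C3=C1CC[C@@H](C)[C@]3(C)Cc1c2[nH]c2ccccc12` nearest: in this assay compound 1 gives 8300 nM, and the only measured step, a 1.8-fold higher number from compound 1 to compound 2 (0.26 log units; within the scatter), stays within the scatter, so no order between the two can be read from it.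

Compound 3 `COC(=O)[C@@]1(C)CC[C@@H]2C3=C1CC[C@@H](C)[C@]3(C)Cc1c2[nH]c2ccc(Br)cc12` is the next member. It differs from compound 2 by bromo in place of methyl on an aromatic carbon. Among the measured compounds shown here, no measured step exchanges one substituent for another at this carbon; the single step available, a 1.8-fold higher number from compound 1 to compound 2 (0.26 log units; within the scatter), only shows that putting a methyl onto that carbon moved the number by less than the scatter. On that basis no step beyond the scatter is expected in this assay for compound 3 either, in no particular direction. The estimate for compound 3 in this assay is therefore 13000 nM, with a range from 5000 nM to 35000 nM, which corresponds to an expected step of a 1.2-fold lower number from compound 2 to compound 3 (0.06 log units; within the scatter).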

Compound 3, concentration for 50% growth inhibition: 12000 nM
For compound 3 the middle estimate is 1.1-fold (0.03 log units) above the measured one, and the stated range covers the measured number.
By their numbers in this assay, from the lowest: compounds 1, 3 and 2 (each within the scatter of the next).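

Among the compounds shown here, with compound 3, a non-carbon substituent at this aromatic carbon is measured for the first time, and a direct exchange of one substituent for another can be read there: in this assay bromo in place of methyl gives a 1.3-fold lower number from compound 2 to compound 3 (0.10 log units; within the scatter) while bromo in place of hydrogen gives a 1.4-fold higher number from compound 1 to compound 3 (0.16 log units; within the scatter) and both steps stay inside the usual spread of repeated measurements. Hydrogen, methyl and bromo at this carbon therefore cannot be put in any order, and none of the three changes available so far moves the number beyond the scatter. No measured information is available to account for this result.

Going by these compounds, what an amine, a carboxylic acid or a longer alkyl chain on this carbon would do in this assay remains open, as does whether any group here can move the number beyond the scatter at all. The compounds shown differ only at this one carbon, so they also leave open how bromo or methyl would behave on another carbon of the same aromatic ring, and how changes elsewhere on the shared core would read.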